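Swapping Fluoro for Methoxy on a Shared Core

A few compounds are considered here, and "the series" means these few. Any claim that something is new, unique, unknown or untested is made for them only; others in the source may bear on it.

Compound 1 `Nc1cc(N)c2nc(-c3ccccc3)c(Sc3ccc(F)cc3)nc2c1` carries a (4-fluorophenyl)sulfanyl group on a shared core. In a functional assay on DU-145 cells (Homo sapiens) for inhibition, read by sulforhodamine B assay, with a stated time of 48 h (on this read-out lower numbers stand for stronger inhibition of growth and higher numbers for weaker inhibition of growth), compound 1 gives only a limit of the assay, < 100000 nM, so no number fixes its position. Among the compounds with values here, a related compound 2 `COc1ccc(CNc2nc3cc(N)cc(N)c3nc2-c2ccccc2)cc1`, bearing a different group on the same core, in this assay gives 57500 nM, the only full number in the set, and it points to weak growth inhibition for this core. Compound 3 `COc1ccc(Sc2nc3cc(N)cc(N)c3nc2-c2ccccc2)cc1` is compound 1 with methoxy in place of fluoro on an aromatic carbon. Within the data shown here, no step between two measured compounds guides this change, and the weak value of compound 2 suggests that compound 3 will also sit at the weak end. The step that the limit leaves unreadable from compound 1 to compound 3 is expected to be small, not beyond the scatter, in either direction. Compound 3 is estimated at 50000 nM, within 15000 nM and 100000 nM.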

Compound 3, concentration for total growth inhibition: 33100 nM
Compound 3: the middle estimate sits 1.5-fold (0.18 log units) above what was measured, within the range that was stated.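

No size can be read for the change from compound 1 to compound 3, and the value of compound 1 is a limit of the assay: the limit of < 100000 nM in this assay, at which 1 of the 3 values shown sits.

The compounds shown leave open whether methoxy in place of fluoro on the shared core changes growth inhibition at all, and in which direction.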